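This account rests on a few compounds, and the source may have more. Where it says the series, first, only, none or still open, it means among the compounds named here.

Compound 1 `COc1cc2c(Oc3ccc(NC(=O)/C=C/S(=O)(=O)c4ccccc4F)cc3F)ccnc2cc1OCCCN1CCN(C)CC1` gives 280 nM in a functional assay on MKN-45 cells (Homo sapiens) for cytotoxicity, read by MTT assay, with a stated time of 72 h; a lower number here means a stronger inhibitor, a higher number a weaker inhibitor.
Compound 2 `COc1cc2c(Oc3ccc(NC(=O)/C=C/S(=O)(=O)c4ccccc4OC)cc3F)ccnc2cc1OCCCN1CCN(C)CC1` gives 430 nM in this assay.

Compound 2 stands beside compound 1 on the numbers shown, the one measured step being a 1.5-fold higher number from compound 1 to compound 2 (0.19 log units; within the scatter), a change on an aromatic carbon far from the chain. Compound 3 `COc1cc2c(Oc3ccc(NC(=O)/C=C/S(=O)(=O)c4ccccc4OC)cc3F)ccnc2cc1OCCCN1CCCCC1` differs from compound 2 by piperidin-1-yl in place of 4-methylpiperazin-1-yl on a saturated chain carbon, three bonds along the chain from an oxygen on an aromatic ring. No measured step touches this end of the molecule, so nothing shown bears on it, and no step beyond the scatter is expected in this assay. Compound 3 is therefore estimated at 430 nM, within 200 nM to 950 nM, a step of no change at the digits printed from compound 2 to compound 3 (within the scatter) expected to lie within the scatter.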

Compound 3, half-maximal inhibitory concentration: 980 nM
Beside the measured number, compound 3's estimate is 2.3-fold (0.36 log units) below it, outside the stated range (above it).
By their numbers in this assay, from the lowest: compounds 1 and 2 (each within the scatter of the next); then compound 3.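

Among the compounds shown here, the end of the chain matters in this assay: replacing 4-methylpiperazin-1-yl with piperidin-1-yl gives a modest step beyond the scatter (a 2.3-fold higher number from compound 2 to compound 3 (0.36 log units; beyond the scatter)), whereas the one earlier step, on an aromatic carbon, stayed within it. This position therefore responds to a change in the ring at the end of the 3-carbon-linked propyl chain. No evidence available here accounts for the step.

On these data alone, it remains open whether the ring nitrogen or the N-methyl group carries the difference, and whether morpholin-4-yl or dimethylamino would follow piperidin-1-yl. The same exchange on the fluoro-substituted compound 1 is also unresolved.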